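From Fluoro to Benzyloxy on a Shared Core

The source may hold more compounds than are shown below. What is called first, only, known or untested is meant among the compounds shown, and "the series" means these compounds.

Measured so far in a functional assay on MCF7 cells (Homo sapiens) for antiproliferative activity, read by MTT assay, with a stated time of 48 h; on this read-out lower numbers stand for stronger inhibition and higher numbers for weaker inhibition:
- Compound 1 `CC(=O)N1N=C(c2ccc3ccccc3c2)OC1c1ccc(Br)cc1` gives 5.07 ug/mL
- Compound 2 `CC(=O)N1N=C(c2ccc3ccccc3c2)OC1c1ccc(Cl)cc1` gives 2.63 ug/mL
- Compound 3 `CC(=O)N1N=C(c2ccc3ccccc3c2)OC1c1ccc(F)cc1` gives 3.02 ug/mL

Compound 3 stands at 3.02 ug/mL among these numbers, and no measured step separates it from the other two beyond the scatter. The steps that reach it are a 1.1-fold higher number from compound 2 to compound 3 (0.06 log units; within the scatter) and a 1.7-fold lower number from compound 1 to compound 3 (0.23 log units; within the scatter) in size, and the remaining one is a 1.9-fold lower number from compound 1 to compound 2 (0.29 log units; within the scatter) in size.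

Compound 4 `CC(=O)N1N=C(c2ccc3ccccc3c2)OC1c1ccc(OCc2ccccc2)cc1` brings a single change to compound 3, benzyloxy in place of fluoro on an aromatic carbon with the rest of the structure kept.

Only the exchanges among bromo, chloro and fluoro at that carbon bear on this change, and none of them tests a group carrying its own ring. They show no large move, but they cannot exclude one, so only a modest shift toward a higher number is expected. The expected change is a 1.7-fold higher number from compound 3 to compound 4 (0.22 log units; within the scatter) in size, with real uncertainty about it. Compound 4 is estimated at 5 ug/mL in this assay, with an expected range from 1.5 ug/mL to 18 ug/mL as its bounds.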

Compound 4, half-maximal inhibitory concentration: 5.49 ug/mL
Beside the measured number, compound 4's estimate is 1.1-fold (0.04 log units) below it; measured number inside the range.
By their numbers in this assay, from the lowest: compounds 2, 3, 1 and 4 (each within the scatter of the next, the first and the last beyond it).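

Benzyloxy brings a group with its own six-membered aromatic ring to this position, and in this assay the exchange for fluoro gives a 1.8-fold higher number from compound 3 to compound 4 (0.26 log units; within the scatter) while the exchange for bromo gives a 1.1-fold higher number from compound 1 to compound 4 (0.03 log units; within the scatter) with neither step leaving the scatter. Against chloro the same group gives a 2.1-fold higher number from compound 2 to compound 4 (0.32 log units; beyond the scatter) as a modest step, the only one at this position among these compounds to pass the scatter, so a far larger group at this carbon moves the number only slightly. No measurement shown offers an explanation for these numbers.

The compounds shown leave open how an amine, a carboxylic acid or a small methoxy group would read at this carbon. They also leave open whether a change elsewhere on the shared core would move the number further than any exchange at this position has.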